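The source may hold more compounds than are shown below. What is called first, only, known or untested is meant among the compounds shown, and "the series" means these compounds.

Of the compounds shown here, three have numbers so far in a functional assay on MV4-11 cells (Homo sapiens) for antiproliferative activity, read by luminescence, with a stated time of 72 h (a lower number here means a stronger inhibitor, a higher number a weaker inhibitor), and all of them sit in the low micromolar region. Compound 1 (`C=CS(=O)(=O)NC/C=C/c1cc(OC)cc(O)c1C(=O)OCC1CCCCC1`) gives a value of 5860 nM and has a different core from the other two. Compound 2 (`COc1cc(O)c(C(=O)OCC(C)c2ccccc2)c(/C=C/CN2C(=O)C=CC2=O)c1`) gives 3380 nM in this assay while compound 3 (`COc1cc(O)c(C(=O)OC(C)C)c(/C=C/CN2C(=O)C=CC2=O)c1`) gives 1730 nM on the same core. Compound 3 therefore stands level with compound 2 within the scatter, and its number lies clearly under that of compound 1.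

Compound 4 (`COc1cc(O)c(C(=O)OCC2CCCCC2)c(/C=C/CN2C(=O)C=CC2=O)c1`) keeps the core of compound 3 and changes one group (cyclohexylmethyl in place of isopropyl on an oxygen next to a carbonyl group), with cyclohexylmethyl in place of isopropyl on an oxygen next to a carbonyl group. Among the measured compounds shown here, only one measured step touches this place, the exchange of 2-phenylpropyl for isopropyl, and it reads a 2.0-fold lower number from compound 2 to compound 3 (0.29 log units; within the scatter) so that swapping a ring-bearing group there moved the number by no more than the scatter. Compound 1 also carries cyclohexylmethyl, but its value (5860 nM) comes with a different core and makes no clean comparison.

No step beyond the scatter is therefore expected in this assay and any drift should be slight, towards a higher number. The expected step is a 1.4-fold higher number from compound 3 to compound 4 (0.14 log units; within the scatter) and that is only an estimate. Compound 4 is estimated at 2400 nM with an expected range of 1000 nM to 5500 nM in this measurement.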

Compound 4, half-maximal inhibitory concentration: 1970 nM
Compound 4: the middle estimate sits 1.2-fold (0.09 log units) above what was measured; the measured number falls inside the stated range.
By their numbers in this assay, from the lowest: compounds 3, 4, 2 and 1 (each within the scatter of the next, the first and the last beyond it).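

Replacing isopropyl with cyclohexylmethyl on an oxygen next to a carbonyl group, which adds a six-membered non-aromatic ring of carbon only, gives in this assay a 1.1-fold higher number from compound 3 to compound 4 (0.06 log units; within the scatter) and so shows that this place tolerates a much larger group on the shared core without a readable change. The comparison with the 2-phenylpropyl group of compound 2 reads a 1.7-fold lower number from compound 2 to compound 4 (0.23 log units; within the scatter) and leaves compounds 2, 3 and 4 all within the scatter of one another, so these three groups cannot be told apart here. The new compound also allows a clean comparison with compound 1, since both carry cyclohexylmethyl: exchanging the open-chain, sulfur-containing group of compound 1 for the group with a five-membered non-aromatic ring gives a 3.0-fold lower number from compound 1 to compound 4 (0.47 log units; beyond the scatter) and is a modest change beyond the scatter, placing the only readable difference at that other site.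

From the compounds shown here alone, what an amine, a carboxylic acid or a longer chain on this oxygen would do remains open. Nothing available explains why the numbers fall as they do.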